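The source may hold more compounds than are shown below. What is called first, only, known or untested is meant among the compounds shown, and "the series" means these compounds.

Measured so far:
compound 1 `CC1=C(C(C)C(=O)N(C)CCN(C)C)c2cc(F)ccc2/C1=C\c1ccc([S+](C)[O-])cc1` — 11900 nM
compound 2 `CC1=C(C(C)C(=O)N(CCNC(C)C)C(C)C)c2cc(F)ccc2/C1=C\c1ccc([S+](C)[O-])cc1` — 8060 nM

In a functional assay on HT-29 cells (Homo sapiens) for inhibition, read by CellTiter-Glo, with a stated time of 72 h (a lower number here means that less compound is tolerated, a higher number that more compound is tolerated), compound 2 gives 8060 nM. For the measured compounds named here, it stands at one end of the two numbers, with compound 1 as its only neighbour, and the single step of a 1.5-fold lower number from compound 1 to compound 2 (0.17 log units; within the scatter) lies within the scatter. Compound 3 `CC1=C(C(C)C(=O)N2CCN(c3ccncc3)CC2)c2cc(F)ccc2/C1=C\c1ccc([S+](C)[O-])cc1` differs from compound 2 by 4-(pyridin-4-yl)piperazin-1-yl in place of isopropyl(2-(isopropylamino)ethyl)amino on a carbonyl carbon. Going by the values given here, only that one step bears on this change, and it showed no movement beyond the scatter, so compound 3 is expected to show a 1.1-fold higher number from compound 2 to compound 3 (0.05 log units; within the scatter), nothing beyond the scatter. Compound 3 is therefore estimated at 9000 nM, in the range 3500 nM to 25000 nM.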

Compound 3, half-maximal cytotoxic concentration: 4990 nM
The estimate for compound 3 lay 1.8-fold (0.26 log units) above the measured number, within the range that was stated.
By their numbers in this assay, from the lowest: compounds 3, 2 and 1 (each within the scatter of the next, the first and the last beyond it).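

In this assay, putting 4-(pyridin-4-yl)piperazin-1-yl on the carbonyl carbon in place of the ring-free amino groups gives a 1.6-fold lower number from compound 2 to compound 3 (0.21 log units; within the scatter) and a 2.4-fold lower number from compound 1 to compound 3 (0.38 log units; beyond the scatter). For the compounds shown here, the second is the first step at this position to pass beyond the scatter, though only modestly, so this place accepts a group with two rings and the number can move. Nothing measured here accounts for that shift. The compounds shown leave open whether the piperazine or the pyridin-4-yl part matters more, and whether a phenyl group in place of the pyridin-4-yl would give a similar number.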